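Iodo in Place of Chloro: What to Expect for Compound 4

The source may hold more compounds than are shown below. What is called first, only, known or untested is meant among the compounds shown, and "the series" means these compounds.

Compound 1 `COc1ccc(-c2cc(=O)c3c(OC)cc(OC)cc3[nH]2)cc1` gives > 31100 nM in a functional assay on KOPN-8 cells (Homo sapiens) for antiproliferative activity, with a stated time of 72 h (on this read-out higher numbers stand for an effect only at larger amounts of compound and lower numbers for an effect already at smaller amounts), which is a limit of the assay rather than a number.
Compound 2 `C=CCNC(=O)n1c(-c2ccc(OC)cc2)cc(=O)c2c(OC)cc(OC)cc21` gives 12000 nM in this assay.
Compound 3 `COc1ccc(-c2c(Cl)c(=O)c3c(OC)cc(OC)cc3n2S(=O)(=O)c2ccc(OC)cc2)cc1` gives 19100 nM in this assay.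

Compound 3 and compound 2 lie within the scatter of each other in this assay, so neither can be placed above the other. Compound 1 contributes only a limit. For the measured compounds named here, the single measured step, an at least 2.5-fold lower number from compound 1 to compound 2 (0.41 log units; beyond the scatter), concerns a change on the ring nitrogen and does not touch the halogen. Compound 4 `COc1ccc(-c2c(I)c(=O)c3c(OC)cc(OC)cc3n2S(=O)(=O)c2ccc(OC)cc2)cc1` differs from compound 3 by iodo in place of chloro on an aromatic carbon. Going by the values given here, no measured step bears on this exchange, so no shift beyond the scatter is expected in this assay. Compound 4 is therefore estimated at 16000 nM, with a range from 6000 nM to 40000 nM, meaning an expected step of a 1.2-fold lower number from compound 3 to compound 4 (0.08 log units; within the scatter).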

Compound 4, half-maximal effective concentration: 8580 nM
Compound 4: the middle estimate sits 1.9-fold (0.27 log units) above what was measured, and the stated range covers the measured number.
By their numbers in this assay, from the lowest: compounds 4, 2 and 3 (each within the scatter of the next, the first and the last beyond it). At a limit, above all of these: compound 1.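

In this assay iodo in place of chloro brings a 2.2-fold lower number from compound 3 to compound 4 (0.35 log units; beyond the scatter) and so shows that the choice of halogen on this aromatic carbon has a modest effect on the number. For the compounds shown here, the earlier compounds offered only a step on the ring nitrogen, so this is the first sign that the read-out responds to a change at this carbon, ortho to the 4-methoxyphenyl group. Nothing shown says why the exchange has this effect. From the compounds shown here alone, whether bromo or fluoro would follow the same trend stays open, as does the effect of an amine at this carbon.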